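Swapping a Furan for a Pyridine in Compound 4

The compounds below may be only part of what the source reports. "The series", "measured", "known", "first", "only" and "open" are said of these compounds alone.

Compound 2 `Oc1ccccc1-c1cc(-c2ccco2)cc(-c2ccccc2O)n1` carries two 2-hydroxyphenyl groups and a furan-2-yl group on its shared core. In a functional assay on T47D cells (Homo sapiens) for cytotoxicity, read by CCK-8 assay (on this read-out lower numbers stand for stronger inhibition and higher numbers for weaker inhibition), compound 2 gives only a limit of the assay, > 50000 nM. Compound 1 `Oc1ccccc1-c1cc(-c2cccs2)cc(-c2ccccc2O)n1`, which carries thiophen-2-yl in place of the furan, also sits at a limit in this assay, > 50000 nM. The step that the two limits leave unreadable from compound 1 to compound 2 cannot be read because the limit of > 50000 nM in this assay, at which 2 of the 3 values shown sit, covers both values. Compound 3 `Oc1cccc(-c2cc(-c3ccco3)cc(-c3ccccc3O)n2)c1`, with 3-hydroxyphenyl in place of one 2-hydroxyphenyl, gives 820 nM in this assay, and the step of an at least 60-fold lower number from compound 2 to compound 3 (1.78 log units; beyond the scatter) is large; it changes a different place on the core than the one considered next.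

Compound 4 `Oc1ccccc1-c1cc(-c2cccnc2)cc(-c2ccccc2O)n1` has not yet been measured. It differs from compound 2 in one place: pyridin-3-yl in place of furan-2-yl on an aromatic carbon. Among the compounds with values here, the only measured step that touches this same place is a step that the two limits leave unreadable from compound 1 to compound 2, and it is unreadable, so the data give no sign of movement here. The expected step of a number no higher from compound 2 to compound 4 (the limit leaves the size open) is therefore none beyond the scatter. Compound 4 is expected to give about 50000 nM in this assay, within a range from 15000 nM to 200000 nM, most likely again as a limit.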

Compound 4, half-maximal inhibitory concentration: > 50000 nM
Compound 4 ended at the assay's limit; the forecaster's own chance of this, stated with the estimate: 70%; the middle value lies on the limit itself.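

Within the data shown here, no step among compound 1, compound 2 and compound 4 can be read in this assay, because all three stop at the same limit rather than giving a number: the limit of > 50000 nM in this assay, at which 3 of the 4 values shown sit. The compounds shown leave open whether thiophen-2-yl, furan-2-yl and pyridin-3-yl differ at all in this place on the shared core.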